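From 2-chlorobenzyl to 2-fluorobenzyl: compound 1 to compound 3

This account rests on a few compounds, and the source may have more. Where it says the series, first, only, none or still open, it means among the compounds named here.

Within the data shown here, in a functional assay on MDA-MB-231 cells (Homo sapiens) for cytotoxicity, read by MTT assay, with a stated time of 24 h (a lower number here means a stronger inhibitor, a higher number a weaker inhibitor), compound 1 `O=C1/C(=C/c2ccccc2F)CN(C(=S)SCc2cn(Cc3ccccc3Cl)nn2)C/C1=C\c1ccccc1F` gives 100000 nM, the higher of the two numbers so far. Compound 2 `Cc1ccc(/C=C2\CN(Cc3cn(Cc4ccc(F)cc4)nn3)C/C(=C\c3ccc(C)cc3)C2=O)cc1` gives 26800 nM, a lower number by more than the usual scatter, but the two compounds differ in more than one place.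

Compound 3 `O=C1/C(=C/c2ccccc2F)CN(C(=S)SCc2cn(Cc3ccccc3F)nn2)C/C1=C\c1ccccc1F` departs from compound 1 at a single place: fluoro in place of chloro on an aromatic carbon. This is fluoro in place of chloro on an aromatic carbon, ortho to a large group, so that 2-chlorobenzyl becomes 2-fluorobenzyl. Among the measured compounds shown here, no measured pair isolates this change in this assay. The expected step is small and not beyond the scatter, with the estimate being a 1.4-fold lower number from compound 1 to compound 3 (0.15 log units; within the scatter). Its slight lean toward a lower number rests only on compound 1 standing at 100000 nM, the top of the measured values. For compound 3 the estimated value is 70000 nM, with an expected range from 30000 nM to 150000 nM.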

Compound 3, half-maximal inhibitory concentration: 57600 nM
Compound 3: the middle estimate sits 1.2-fold (0.08 log units) above what was measured, and the stated range covers the measured number.
By their numbers in this assay, from the lowest: compound 2; then compounds 3 and 1 (each within the scatter of the next).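

In this assay, among these compounds, the change from 2-chlorobenzyl to 2-fluorobenzyl gives a 1.7-fold lower number from compound 1 to compound 3 (0.24 log units; within the scatter), the first step that isolates a single place. On this pair, fluoro and chloro on this aromatic carbon cannot be told apart, as the step stays within the scatter and gives no basis for ranking the two halogens here. Nothing available explains this outcome.

The pair covers only chloro and fluoro at this position, so it cannot show how an amine or a carboxylic acid would read there. From the compounds shown here alone, whether the same exchange would also stay within the scatter on a core other than that of compound 1 remains open.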